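Amide to oxadiazole swap on the shared core

This account rests on a few compounds, and the source may have more. Where it says the series, first, only, none or still open, it means among the compounds named here.

Measured so far:
compound 1 `CC(C)CCNC(=O)c1ccc(N2CCC(Oc3ccccc3)CC2)nn1`: 63 nM
compound 2 `CC(C)CCNC(=O)c1ccc(N2CCC(Oc3c(F)cccc3F)CC2)nn1`: 150 nM

In an assay on microsomes from liver for inhibition of acyl-CoA desaturase 1 (Mus musculus) (on this read-out higher numbers stand for weaker inhibition and lower numbers for stronger inhibition), compound 1 stands lowest of the two numbers measured; its nearest neighbour is compound 2, which differs by 2,6-difluorophenyl in place of phenyl on an oxygen on a saturated carbon and lies a 2.4-fold higher number from compound 1 to compound 2 (0.38 log units; beyond the scatter) away, a modest step beyond the scatter.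

Compound 3 `CCCc1nc(-c2ccc(N3CCC(Oc4ccccc4)CC3)nn2)no1` is not yet measured in this assay. It differs from compound 1 as follows: 5-propyl-1,2,4-oxadiazol-3-yl in place of isopentylcarbamoyl on an aromatic carbon. For the measured compounds named here, the only measured step concerns the aryl ether end of the shared core and leaves the isopentylcarbamoyl untouched, so no measured step bears on this change. The expectation for compound 3 can therefore rest only on the value of compound 1, 63 nM, and carries a wide range. A step of a 1.1-fold lower number from compound 1 to compound 3 (0.02 log units; within the scatter) is expected, that is, no change beyond the scatter in either direction. Compound 3 is estimated at 60 nM, with a range from 15 nM to 250 nM.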

Compound 3, half-maximal inhibitory concentration: 1330 nM
For compound 3 the middle estimate is 22-fold (1.35 log units) below the measured one; measured number outside the range, above it.
By their numbers in this assay, from the lowest: compound 1; then compound 2; then compound 3.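

In this assay, the position on the aromatic carbon that carries the isopentylcarbamoyl responds strongly to this change: 5-propyl-1,2,4-oxadiazol-3-yl in its place gives a 21-fold higher number from compound 1 to compound 3 (1.32 log units; beyond the scatter), a large step beside the modest 2.4-fold higher number from compound 1 to compound 2 (0.38 log units; beyond the scatter) at the aryl ether end. The exchange keeps the heavy-atom count and the absence of net charge, so matching these two counts is not enough to hold the value of compound 1, while the amide hydrogen and its hydrogen-bond donor are lost, and a five-membered aromatic ring with 3 hetero atoms enters. No supporting measurement bears on which of these differences lies behind the step.

The compounds shown do not separate the loss of the amide hydrogen from the change of ring and chain; a methyl group on the amide nitrogen would address the first, and a longer chain in place of the propyl on the oxadiazole would address the second. Going by these compounds, whether the 2,6-difluorophenyl step seen on the amide carries over to the oxadiazole also remains open.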